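Cytotoxicity of a shortened alkynol chain

The source may report more compounds than this note shows. Statements on the series, on what has been measured and on what is new or still open speak of the compounds shown alone.

Measured in an ADME assay on HEL cells (Homo sapiens) for cytotoxicity, read by cell counting, with a stated time of 3 days; a lower number here means that less compound is tolerated, a higher number that more compound is tolerated:
- Compound 1 `CCCCCc1ccc(-c2oc3nc(=O)n([C@H]4C[C@H](OC(C)=O)[C@@H](COC(C)=O)O4)cc3c2C#Cc2ccc(C)cc2)cc1`: "not determined" (no result reported)
- Compound 2 `CCCCCc1ccc(-c2oc3nc(=O)n([C@H]4C[C@H](OC(C)=O)[C@@H](COC(C)=O)O4)cc3c2C#CCCO)cc1`: 2660 nM

Among the measured compounds shown here, compound 2, at 2660 nM, holds the only number in this assay, so it cannot yet be ranked against another compound. Compound 3 `CCCCCc1ccc(-c2oc3nc(=O)n([C@H]4C[C@H](OC(C)=O)[C@@H](COC(C)=O)O4)cc3c2C#CCO)cc1` differs from compound 2 in one place: hydroxy in place of hydroxymethyl on a saturated chain carbon bound to a triple-bonded carbon. This puts hydroxy in place of hydroxymethyl on a saturated chain carbon bound to a triple-bonded carbon. For the measured compounds named here, no measured step shows what such a change does here. The estimated step of a 1.1-fold higher number from compound 2 to compound 3 (0.05 log units; within the scatter) is expected to stay within the usual scatter, with neither direction favoured. The expected value for compound 3 is 3000 nM, with an estimated range from 1200 nM to 7500 nM.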

Compound 3, half-maximal cytotoxic concentration: 3800 nM
For compound 3 the middle estimate is 1.3-fold (0.10 log units) below the measured one; the measured number falls inside the stated range.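

Among the compounds shown here, measured in this assay the change from 4-hydroxybut-1-yn-1-yl to 3-hydroxyprop-1-yn-1-yl gives the first step that can be read at this position (a 1.4-fold higher number from compound 2 to compound 3 (0.15 log units; within the scatter)). Hydroxy in place of hydroxymethyl on this saturated chain carbon therefore leaves compound 2 and compound 3 within the scatter of each other. No available evidence bears on this result. The compounds shown leave open whether a longer chain, an amine or a carboxylic acid in this place would also stay within the scatter of compound 2.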